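Chloro in place of trifluoromethyl in a growth-inhibition pair

A few compounds are considered here, and "the series" means these few. Any claim that something is new, unique, unknown or untested is made for them only; others in the source may bear on it.

In a functional assay on LOX IMVI cells (Homo sapiens) for inhibition, read by sulforhodamine B assay, with a stated time of 48 h (on this read-out lower numbers stand for stronger inhibition of growth and higher numbers for weaker inhibition of growth), compound 2 `COc1cc2nc(-c3ccc(C(F)(F)F)cc3)cc(OCCCN3CCCCC3)c2cc1OC` gives 162 nM and compound 1 `COc1cc2nc(-c3ccc(Cl)cc3)cc(OCCCN3CCC(O)CC3)c2cc1OC` gives 227 nM, two values within the usual scatter of each other. Compound 3 `COc1cc2nc(-c3ccc(Cl)cc3)cc(OCCCN3CCCCC3)c2cc1OC` differs from compound 2 in one place, with chloro in place of trifluoromethyl on an aromatic carbon. Among the compounds with values here, no measured pair shows this change on its own, so the expectation rests on these two values alone. In this assay, the expected step of a 1.0-fold higher number from compound 2 to compound 3 (0.02 log units; within the scatter) stays within the scatter, with no direction foreseen. For compound 3 the estimated value is 170 nM, with an expected range of 75 nM to 390 nM.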

Compound 3, concentration for 50% growth inhibition: 189 nM
Estimate against measurement, compound 3: 1.1-fold (0.05 log units) below, and the stated range covers the measured number.
By their numbers in this assay, from the lowest: compounds 2, 3 and 1 (each within the scatter of the next).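

In this assay the change from 4-(trifluoromethyl)phenyl to 4-chlorophenyl gives a 1.2-fold higher number from compound 2 to compound 3 (0.07 log units; within the scatter) and so separates the two groups at this aromatic carbon by no more than the scatter. Compound 3 also links the series to compound 1, and hydrogen in place of hydroxy on a saturated ring carbon gives a 1.2-fold lower number from compound 1 to compound 3 (0.08 log units; within the scatter) with the 4-chlorophenyl group held constant. No accompanying evidence bears on either result.
From the compounds shown here alone, whether a nitrile at that aromatic carbon would move the number beyond the scatter remains open. So does the effect of an amine or a carboxylic acid on the saturated ring carbon.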